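A few compounds are considered here, and "the series" means these few. Any claim that something is new, unique, unknown or untested is made for them only; others in the source may bear on it.

Measured so far:
compound 1, `CCCCCCCCCCCCCCCC(=O)OCC(CSC[C@H](NC(=O)OC(C)(C)C)C(=O)N[C@@H](COC(C)(C)C)C(=O)OC)OC(=O)CCCCCCCCCCCCCCC`: 5640 nM
compound 2, `CCCCCCCCCCCCCCCC(=O)OCC(CSC[C@H](NC(C)=O)C(=O)N[C@@H](CO)C(=O)OC)OC(=O)CCCCCCCCCCCCCCC`: 5 nM

In an assay on HEK-Blue hTLR2-TLR6 cells for agonist activity at TLR2/TLR6 (Homo sapiens), read by reporter gene assay (on this read-out higher numbers stand for an effect only at larger amounts of compound and lower numbers for an effect already at smaller amounts), compound 1 gives 5640 nM, the highest of the two numbers; compound 2 gives 5 nM, a much lower number, beyond the scatter. Among the compounds with values here, no step between measured compounds is available. Compound 3, `CCCCCCCCCCCCCCCC(=O)OC[C@H](CSC[C@H](NC(=O)OC(C)(C)C)C(=O)N[C@@H](COC(C)(C)C)C(=O)OC)OC(=O)CCCCCCCCCCCCCCC`, differs from compound 1 only in that (the two compounds have the same atoms and bonds; at least one stereo element is drawn with a configuration in one of them and without one in the other: 1 of 3 stereo elements differ; a stereocentre at a saturated chain carbon is drawn without a configuration in compound 1 and R in compound 3). With the same atoms and bonds, a step from compound 1 to compound 3 is expected to be at most a small one towards a lower number, a 2.0-fold lower number from compound 1 to compound 3 (0.30 log units; within the scatter), possibly not beyond the scatter. Compound 3 is therefore estimated at 2800 nM in this assay, within 900 nM to 8000 nM.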

Compound 3, half-maximal effective concentration: 5870 nM
Beside the measured number, compound 3's estimate is 2.1-fold (0.32 log units) below it, within the range that was stated.
By their numbers in this assay, from the lowest: compound 2; then compounds 1 and 3 (each within the scatter of the next).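

In this assay the stereocentre at a saturated chain carbon, drawn as R in compound 3, leaves the read-out within the scatter (a 1.0-fold higher number from compound 1 to compound 3 (0.02 log units; within the scatter)). For compounds carrying these tert-butyl groups, drawing this configuration therefore goes with no measurable difference. The comparison rests on a single difference: the fact that one of compounds 1 and 3 is drawn with a defined configuration and the other without, at the place where they differ.

Going by these compounds, the S configuration at this carbon remains open, as does whether the same holds for the free hydroxyl and acetyl form of compound 2. Also open, on these data alone, is how a carboxylic acid in place of the methyl ester would read.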